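The source may report more compounds than this note shows. Statements on the series, on what has been measured and on what is new or still open speak of the compounds shown alone.

Measured compounds in the series:
compound 1 `O=C(NO)c1ccc(NCc2nc(-c3ccccc3)nn2-c2ccc(Br)cc2)cc1` — 1730 nM
compound 2 `O=C(NO)c1ccc(NCc2nc(-c3ccc(F)cc3)nn2-c2ccccc2)cc1` — 115 nM
compound 3 `O=C(NO)c1ccc(NCc2nc(-c3ccccc3)nn2-c2ccc(F)cc2)cc1` — 274 nM

All three were run in an assay on Sf9 cells for inhibition of protein deacetylase HDAC6 (Homo sapiens), read by fluorescence, with a stated time of 40 min; on this read-out lower numbers stand for stronger inhibition and higher numbers for weaker inhibition. Compound 2 stands lowest of the three numbers in this assay; the nearest is compound 3 with 274 nM, the furthest is compound 1 with 1730 nM, and both gaps lie beyond the scatter. Going by the values given here, compound 2 and compound 3 carry the same set of atoms and differ only in where the fluorine sits, so their values show that this placement matters, though no single step is counted between them.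

Compound 4 `Cc1ccsc1-c1nc(CNc2ccc(C(=O)NO)cc2)n(-c2ccccc2)n1` is the next candidate. The change from compound 2 is 3-methylthiophen-2-yl in place of 4-fluorophenyl on an aromatic carbon, on the aromatic carbon of the five-membered aromatic ring with three nitrogen, between two ring nitrogen atoms. Among the compounds with values here, no measured step alters the group on this carbon. Within the data shown here, the only counted step, a 6.3-fold lower number from compound 1 to compound 3 (0.80 log units; beyond the scatter), concerns the halogen on the ring that hangs from the ring nitrogen, so it bears on the present change only loosely. One ring replaces another of similar size, so a modest step in this assay is expected, in either direction, with a drift toward a higher number held as the more likely outcome. Compound 4 is therefore estimated at 200 nM in this assay, within 80 nM to 500 nM, which is expected to mean a 1.7-fold higher number from compound 2 to compound 4 (0.24 log units; within the scatter).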

Compound 4, half-maximal inhibitory concentration: 30.7 nM
Beside the measured number, compound 4's estimate is 6.5-fold (0.81 log units) above it, and the stated range ends above it.
By their numbers in this assay, from the lowest: compound 4; then compound 2; then compound 3; then compound 1.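

In this assay, going by these compounds alone, a 3.7-fold lower number from compound 2 to compound 4 (0.57 log units; beyond the scatter), the first counted step at the aromatic carbon between two ring nitrogen atoms, shows that the number responds to the group held at this position. Among the compounds shown, a 4-fluorophenyl group is not needed here: 3-methylthiophen-2-yl, a five-membered aromatic ring with 1 hetero atom and 6 heavy atoms in place of 7, is accepted and gives a lower number, beyond the scatter. No measured evidence is available to account for this step or to assign it to any feature of the entering group.

The exchange alters ring size, brings in sulfur, moves from fluorine to methyl and removes the halogen in a single step, so the compounds shown leave open which of these changes carries the effect; an unsubstituted thiophen-2-yl group or a 3-methylphenyl group at this carbon would separate them. Also open, going by these compounds, is whether 3-methylthiophen-2-yl gives a similar step when the phenyl group on the ring nitrogen carries fluoro or bromo, the change behind a 6.3-fold lower number from compound 1 to compound 3 (0.80 log units; beyond the scatter).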